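Trading a Small Alkoxy Group for a Hydroxylated Ring

The compounds below may be only part of what the source reports. "The series", "measured", "known", "first", "only" and "open" are said of these compounds alone.

Measured compounds:
compound 1, `COc1cc(C(=O)N(C)C)ccc1Nc1nc(OC(C)C)c2cc[nH]c2n1`, 1270 nM
compound 2, `CCOc1cc(C(=O)N(C)C)ccc1Nc1nc(O[C@H]2CC[C@@](C)(O)CC2)c2cc[nH]c2n1`, 26 nM
compound 3, `CN(C)C(=O)c1ccc(Nc2nc(O[C@H]3CC[C@@](C)(O)CC3)c3cc[nH]c3n2)c(OCC(F)(F)F)c1`, 15 nM

In a functional assay on CAL-51 cells (Homo sapiens) for antiproliferative activity, read by luminescence and CellTiter-Glo, with a stated time of 3 days (on this read-out higher numbers stand for weaker inhibition and lower numbers for stronger inhibition), compound 1 gives the highest of the three numbers, so it is the weakest inhibitor shown; compound 2 and compound 3 sit far below it, and the gaps to both are well beyond the scatter. Compound 4, `COc1cc(C(=O)N(C)C)ccc1Nc1nc(O[C@H]2CC[C@](C)(O)CC2)c2cc[nH]c2n1`, is not yet measured. It differs from compound 1 in one place: 4-hydroxy-4-methylcyclohexyl in place of isopropyl on an oxygen on an aromatic ring.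

Within the data shown here, no measured pair tests this exact change on its own. Compound 2 and compound 3 both carry the entering group, but each also differs from compound 1 at a second place, so their distance from compound 1 cannot be credited to the ring alone. Among the measured compounds shown here, the one clean step, a 1.7-fold lower number from compound 2 to compound 3 (0.24 log units; within the scatter), concerns that second place and stays within the scatter, which hints that the second place matters little and that most of the gap between compound 1 and compound 2 comes from the group that enters here.

Compound 4 is therefore expected to fall far below compound 1, an estimated step of a 21-fold lower number from compound 1 to compound 4 (1.33 log units; beyond the scatter). The estimate for compound 4 is 60 nM, with a range from 15 nM to 250 nM.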

Compound 4, half-maximal inhibitory concentration: 69 nM
The estimate for compound 4 lay 1.2-fold (0.06 log units) below the measured number; measured number inside the range.
By their numbers in this assay, from the lowest: compounds 3 and 2 (each within the scatter of the next); then compound 4; then compound 1.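

Among these compounds, until this result, the hydroxylated ring had appeared only alongside a second difference from compound 1. Here it stands alone: in this assay, placing 4-hydroxy-4-methylcyclohexyl on the oxygen in place of isopropyl, with the rest of the molecule unchanged, gives an 18-fold lower number from compound 1 to compound 4 (1.26 log units; beyond the scatter) and so shows that this single change is enough to produce a large step. The change bundles several things together, however, adding a ring, more carbon, and a hydrogen-bond donor and acceptor, and one step cannot show which of these matters.

The compounds shown leave open whether the ring or its hydroxyl carries the gain, a question that a plain cyclohexyl, or a cyclohexyl with an amine in place of the hydroxyl, would help to settle. No supporting evidence is available to explain why this larger group gives the lower number.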